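Replacing 4-chlorophenyl with 3-nitrophenyl on a shared core

This account rests on a few compounds, and the source may have more. Where it says the series, first, only, none or still open, it means among the compounds named here.

In an ADME assay on L02 cells (Homo sapiens) for cytotoxicity, read by MTT assay, with a stated time of 24 h (a higher number here means a weaker inhibitor, a lower number a stronger inhibitor), compound 3 `COc1cc(/C=C2\CN(C)C/C(=C\c3ccc(Cl)cc3)C2=O)cc(OC)c1OC` gives 14000 nM as its value. This lies within the scatter of compound 2 `COc1cc(/C=C2\CN(C)C/C(=C\c3cc(OC)c(OC)c(OC)c3)C2=O)cc(OC)c1` at 14600 nM and also of compound 1 `COc1cc(/C=C2\CN(C)C/C(=C\c3cccc([N+](=O)[O-])c3)C2=O)cc(OC)c1` at 10800 nM in the same measurement, so these numbers cannot be ranked. Compound 1 also carries a 3-nitrophenyl group. Compound 4 `COc1cc(/C=C2\CN(C)C/C(=C\c3cccc([N+](=O)[O-])c3)C2=O)cc(OC)c1OC` differs from compound 3 by a single swap: 3-nitrophenyl in place of 4-chlorophenyl on a double-bonded chain carbon bound to a double-bonded ring carbon on a double-bonded chain carbon bound to a double-bonded ring carbon. Within the data shown here, the one measured step at this place is a 1.0-fold lower number from compound 2 to compound 3 (0.02 log units; within the scatter) and it gives no sign of a large effect. The expected step is a 1.1-fold lower number from compound 3 to compound 4 (0.05 log units; within the scatter) in this assay and nothing beyond the scatter is expected. For compound 4 the estimated value is 12500 nM with an expected range from 7500 nM to 21000 nM in this measurement.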

Compound 4, half-maximal inhibitory concentration: 13600 nM
The estimate for compound 4 lay 1.1-fold (0.04 log units) below the measured number, within the range that was stated.
By their numbers in this assay, from the lowest: compounds 1, 4, 3 and 2 (each within the scatter of the next).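

In this assay, 3-nitrophenyl in place of 4-chlorophenyl gives a 1.0-fold lower number from compound 3 to compound 4 (0.01 log units; within the scatter) and 3-nitrophenyl in place of 3,5-dimethoxyphenyl gives a 1.1-fold lower number from compound 2 to compound 4 (0.03 log units; within the scatter) at this place. All three groups tried here therefore leave the number within the scatter on the same core. At a second place, methoxy in place of hydrogen on an aromatic carbon gives a 1.3-fold higher number from compound 1 to compound 4 (0.10 log units; within the scatter) and also stays within the scatter. No measured evidence bears on this result. Still open, from the compounds shown here alone, is whether an amine or a carboxylic acid at this place would shift the number beyond the scatter.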